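Removing One Fluoro Group from Compound 2

The compounds below may be only part of what the source reports. "The series", "measured", "known", "first", "only" and "open" are said of these compounds alone.

Compound 1 `COC(=O)/C(=C/c1ccccc1)CN1C(=O)[C@@H](OC)[C@H]1c1cccc(Cl)c1` no result reported
Compound 2 `COC(=O)/C(=C/c1ccccc1)CN1C(=O)[C@@H](OC)[C@H]1c1cccc(F)c1` 34400 nM

In a functional assay on MDA-MB-231 cells (Homo sapiens) for antiproliferative activity, read by MTT assay, with a stated time of 48 h (a higher number here means a weaker inhibitor, a lower number a stronger inhibitor), compound 2 gives 34400 nM as the only number shown. For compound 1 the entry reads no result reported, so compound 2 cannot yet be placed against another compound. Compound 3 `COC(=O)/C(=C/c1ccccc1)CN1C(=O)[C@@H](OC)[C@H]1c1ccccc1` keeps the rest of compound 2 and differs at one site: hydrogen in place of fluoro on an aromatic carbon with hydrogen in place of fluoro on an aromatic carbon, turning 3-fluorophenyl into phenyl. Within the data shown here, no measured pair shows what such a change does here, so the expectation rests only on compound 2 at 34400 nM and this single replacement. The expected change is a 1.1-fold lower number from compound 2 to compound 3 (0.06 log units; within the scatter) in this assay with no firm direction, and it is not expected to go beyond the usual scatter. Compound 3 is expected to give 30000 nM with an estimated range from 11000 nM to 80000 nM once tested.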

Compound 3, half-maximal inhibitory concentration: 11100 nM
Estimate against measurement, compound 3: 2.7-fold (0.43 log units) above, and the stated range covers the measured number.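

In this assay, replacing fluoro with hydrogen on this aromatic carbon, meta to a large group, gives a 3.1-fold lower number from compound 2 to compound 3 (0.49 log units; beyond the scatter). The change from 3-fluorophenyl to phenyl therefore has a modest effect that lies beyond the scatter, which shows that this position is not indifferent to its substituent and that, of these two, the compound with phenyl is the stronger inhibitor. Nothing available explains why the removal of this single fluoro group has this effect.

Compound 1 carries chloro in the corresponding place but has no number, so chloro cannot be ranked against fluoro or hydrogen here. As far as these compounds go, whether an amine or a hydroxyl group on this aromatic carbon would match the phenyl compound or move the number further also remains open.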